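A Second Halogen Joins the Chlorinated Compound

The compounds below may be only part of what the source reports. "The series", "measured", "known", "first", "only" and "open" are said of these compounds alone.

Compound 1 `c1ccc(C2=NN(c3ccc(-c4ccccc4)nn3)C(c3ccccc3)C2)cc1`: 23800 nM
Compound 2 `Clc1ccc(C2=NN(c3ccc(-c4ccccc4)nn3)C(c3ccccc3)C2)cc1`: 10000 nM

Both compounds were tested in a functional assay on MCF7 cells (Homo sapiens) for antiproliferative activity, read by MTT assay, with a stated time of 24 h; on this read-out lower numbers stand for stronger inhibition and higher numbers for weaker inhibition. Compound 2 gives the lowest of the two numbers; its nearest neighbour is compound 1, whose number is higher. Among the compounds with values here, the single step measured so far is a 2.4-fold lower number from compound 1 to compound 2 (0.38 log units; beyond the scatter), a modest move beyond the scatter. Compound 3 `Fc1ccc(C2CC(c3ccc(Cl)cc3)=NN2c2ccc(-c3ccccc3)nn2)cc1` keeps the chlorine of compound 2 and differs from it in one place: fluoro in place of hydrogen on an aromatic carbon. Seen one bond further out, the change reads phenyl to 4-fluorophenyl. Within the data shown here, only the step from compound 1 to compound 2 is available for comparison, and it concerns a different ring and a different halogen, so it bears on the new change only loosely. The expectation is therefore a small step, either toward a somewhat lower number or none beyond the scatter. On that basis the estimate for compound 3 in this assay is 7000 nM, within a range from 3000 nM to 18000 nM, which would mean a step of a 1.4-fold lower number from compound 2 to compound 3 (0.15 log units; within the scatter).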

Compound 3, half-maximal inhibitory concentration: 3750 nM
For compound 3 the middle estimate is 1.9-fold (0.27 log units) above the measured one, and the stated range covers the measured number.
By their numbers in this assay, from the lowest: compound 3; then compound 2; then compound 1.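

Placing fluoro on an aromatic carbon, para to a large group, gives a 2.7-fold lower number from compound 2 to compound 3 (0.43 log units; beyond the scatter) in this assay and so shows that this ring, untouched between the earlier compounds, also responds to a single added atom. Alongside a 2.4-fold lower number from compound 1 to compound 2 (0.38 log units; beyond the scatter) on the other ring, this makes two halogen steps in the compounds shown, and both lead to a lower number and lie beyond the scatter. No measurement at hand gives a reason for the new step.

The compounds shown leave open whether fluoro is special at this place, since a chlorine, a methoxy group or an amine in the same position could give a lower number, a higher one or no change. They also leave open whether fluoro would give a step of the same size without the chlorine of compound 2, since here it appears only together with that chlorine.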